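Changing the sulfonyl ring on a rapidly cleared compound

A few compounds are considered here, and "the series" means these few. Any claim that something is new, unique, unknown or untested is made for them only; others in the source may bear on it.

Within the data shown here, in an ADME assay on microsomes (Homo sapiens) for metabolic stability (a lower number here means slower removal, a higher number faster removal of the compound), compound 3 (`COC[C@@H]1CCCN1S(=O)(=O)c1ccc(Cl)c(COc2cccc3c(C(F)(F)F)cc(C)nc23)c1Cl`) gives 450 mL/min/kg as the highest of the three numbers so far. Compound 2 (`Cc1cc(C(F)(F)F)c2cccc(OCc3c(Cl)ccc(S(=O)(=O)N4CCC[C@H]4C(N)=O)c3Cl)c2n1`) lies nearest at 167 mL/min/kg and compound 1 (`CNC(=O)[C@@H]1CCCN1S(=O)(=O)c1ccc(Cl)c(COc2cccc3c(-n4ccnc4)cc(C)nc23)c1Cl`) lies furthest at 33.3 mL/min/kg on the lower side.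

Compound 4 (`Cc1cc(C(F)(F)F)c2cccc(OCc3c(Cl)ccc(S(=O)(=O)N4CCCCC4)c3Cl)c2n1`) keeps the core of compound 3 and differs in one place, on a sulfonyl sulfur, where the change is piperidin-1-yl in place of 2-(methoxymethyl)pyrrolidin-1-yl on a sulfonyl sulfur in short. Among the measured compounds shown here, the one measured step at this part of the molecule is a 2.7-fold higher number from compound 2 to compound 3 (0.43 log units; beyond the scatter) with methoxymethyl in place of carbamoyl on a saturated ring carbon. For the measured compounds named here, that step is modest, and no measured pair shows a change of ring size or the loss of the whole side chain, so it offers only a rough guide. The estimated step is a 1.3-fold lower number from compound 3 to compound 4 (0.11 log units; within the scatter) and is expected to stay within the scatter, with a slightly lower number the likelier direction. In this assay compound 4 is expected at 350 mL/min/kg with 150 mL/min/kg to 750 mL/min/kg as the estimated range.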

Compound 4, clearance: 233 mL/min/kg
Compound 4: middle estimate off by 1.5-fold (0.18 log units), on the high side, and the stated range covers the measured number.
By their numbers in this assay, from the lowest: compound 1; then compounds 2, 4 and 3 (each within the scatter of the next, the first and the last beyond it).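

In this assay, replacing 2-(methoxymethyl)pyrrolidin-1-yl on the sulfonyl sulfur with piperidin-1-yl, which has a six-membered ring and no side chain, gives a 1.9-fold lower number from compound 3 to compound 4 (0.29 log units; within the scatter), and replacing 2-carbamoylpyrrolidin-1-yl with it gives a 1.4-fold higher number from compound 2 to compound 4 (0.14 log units; within the scatter). Compound 4 therefore cannot be told apart from either pyrrolidine compound, even though the two pyrrolidine side chains are separated by a 2.7-fold higher number from compound 2 to compound 3 (0.43 log units; beyond the scatter) in the same assay. With this core, the side chain can be removed and the ring enlarged together without a change that stands clear of the scatter, but nothing measured here accounts for this.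

The compounds shown leave open whether morpholin-4-yl on the sulfonyl sulfur, or a pyrrolidine ring carrying a carboxylic acid, would give a number beyond the scatter of compound 4.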